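Aryl Exchange on the Amide-Type Nitrogen: Compound 3 to Compound 4

The source may hold more compounds than are shown below. What is called first, only, known or untested is meant among the compounds shown, and "the series" means these compounds.

Three measured compounds share one core and differ only in the aromatic ring carried by an amide-type nitrogen. Compound 1 `O=C(Nc1ccccc1)Nc1nnc(Sc2ncnc3scc(-c4ccncc4)c23)s1` gives 23300 nM in a functional assay on T47D cells (Homo sapiens) for antiproliferative activity, read by MTT assay, with a stated time of 48 h; on this read-out lower numbers stand for stronger inhibition and higher numbers for weaker inhibition. Compound 2 `Cc1cccc(NC(=O)Nc2nnc(Sc3ncnc4scc(-c5ccncc5)c34)s2)c1` gives 27200 nM in this assay, and compound 3 `O=C(Nc1cccc(Cl)c1)Nc1nnc(Sc2ncnc3scc(-c4ccncc4)c23)s1` gives 43900 nM in this assay. Compound 3 carries the highest of the three numbers, yet the step of a 1.9-fold higher number from compound 1 to compound 3 (0.28 log units; within the scatter) and the step of a 1.6-fold higher number from compound 2 to compound 3 (0.21 log units; within the scatter) both stay within the scatter, as does the step of a 1.2-fold higher number from compound 1 to compound 2 (0.07 log units; within the scatter), so the three compounds cannot be told apart on these data.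

Compound 4 `COc1ccc(NC(=O)Nc2nnc(Sc3ncnc4scc(-c5ccncc5)c34)s2)cc1` has not yet been measured in this assay. Relative to compound 3 the change is 4-methoxyphenyl in place of 3-chlorophenyl on an amide-type nitrogen. Within the data shown here, no measured step puts a methoxy group onto the ring, so the only guidance is that every exchange tried so far on that ring, whether hydrogen, methyl or chloro, has left the numbers inside the scatter. The step from compound 3 to compound 4 is therefore expected to be small, with no direction beyond the scatter, namely a 1.6-fold lower number from compound 3 to compound 4 (0.20 log units; within the scatter). Compound 4 is estimated to give 28000 nM in this assay, within a range from 10000 nM to 70000 nM.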

Compound 4, half-maximal inhibitory concentration: > 100000 nM
Compound 4 gave a limit, no number (the forecaster's own chance of this, stated with the estimate: 15%); at least 3.5-fold (0.55 log units) between middle value and limit.
By their numbers in this assay, from the lowest: compounds 1, 2 and 3 (each within the scatter of the next). At a limit, above all of these: compound 4.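

Compound 4 reads in this assay only as a limit and not as a number: the limit of > 100000 nM in this assay, at which 1 of the 4 values shown sits.

Even so, the ring on the amide-type nitrogen proves less indifferent than compounds 1, 2 and 3 suggested, since this exchange is the first there to go beyond the scatter, with an at least 2.2-fold higher number from compound 3 to compound 4 (0.35 log units; beyond the scatter), an at least 3.6-fold higher number from compound 2 to compound 4 (0.56 log units; beyond the scatter) and an at least 4.2-fold higher number from compound 1 to compound 4 (0.63 log units; beyond the scatter). All three steps run the same way, towards weaker inhibition, whereas hydrogen, methyl and chloro on that ring could not be told apart from one another, so the 4-methoxyphenyl group is the only one shown that separates from the rest.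

The compounds shown leave open whether this step goes with the methoxy group itself or with where it sits, for 3-chlorophenyl and 4-methoxyphenyl differ in both the group and its place on the ring, and no compound shown changes one without the other. They also say nothing about how a hydroxy group, an amine or a longer ether chain such as ethoxy on that ring would read.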